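The source may hold more compounds than are shown below. What is called first, only, known or untested is meant among the compounds shown, and "the series" means these compounds.

Compound 1 `CC(C)(C)c1ccnc(N)n1` gives 32%. Compound 2 `CC(C)(C)Nc1nccc(C(C)(C)C)n1` gives 26%. Compound 3 `CNc1nccc(C(C)(C)C)n1` gives 34%.

These readings come from a functional assay on the whole organism for inhibition, with Rattus norvegicus as the target, with stated times of 1 h and 3.5 h, at a dose of 100 mg/kg by the oral route; on this read-out lower numbers stand for less inhibition and higher numbers for more inhibition at the one dose given (going by the name of the read-out). Compound 3 gives the highest of the three numbers, but its steps to the others, a number 2 percentage points higher from compound 1 to compound 3 (within the scatter) and a number 8 percentage points higher from compound 2 to compound 3 (within the scatter), both fall within the scatter, so the three compounds cannot be told apart. Compound 4 `CSc1nccc(C(C)(C)C)n1` differs from compound 3 by methylsulfanyl in place of methylamino on an aromatic carbon. For the measured compounds named here, none of the measured steps touches this spot: each of them only varies what sits on the nitrogen, such as a number 6 percentage points lower from compound 1 to compound 2 (within the scatter), and all lie within the scatter. Nothing measured points in either direction, so the expected step is a number 4 percentage points lower from compound 3 to compound 4 (within the scatter), not beyond the scatter. Compound 4 is estimated at 30% in this assay, with a range from 10% to 50%.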

Compound 4, a percentage reported as inhibition, in the whole organism at one dose (the size of the read-out at that dose, not a potency): 35%
For compound 4 the middle estimate is 5 percentage points below the measured one; the range from low to high includes it.
By their numbers in this assay, from the lowest: compounds 2, 1, 3 and 4 (each within the scatter of the next).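

In this assay, replacing the nitrogen-linked groups on the aromatic carbon between two ring nitrogen atoms with methylsulfanyl gives a number 1 percentage points higher from compound 3 to compound 4 (within the scatter), a number 3 percentage points higher from compound 1 to compound 4 (within the scatter) and a number 9 percentage points higher from compound 2 to compound 4 (within the scatter). This position therefore accepts a group with sulfur as its linking atom and no hydrogen-bond donor, and the reading stays within the scatter of all three nitrogen-linked compounds. Nothing available explains this result. As far as these compounds go, it remains open whether a longer chain on the sulfur, or a carboxylic acid at this position, would give a reading beyond the scatter.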